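Extending the imine substituent of compound 2 toward a styryl group

The compounds below may be only part of what the source reports. "The series", "measured", "known", "first", "only" and "open" are said of these compounds alone.

The two measured compounds share a fused core, and the value compared here is the cytotoxic concentration read out in an ADME assay on cells (Rhabdomyosarcoma cell, Homo sapiens) for cytotoxicity, read by MTT assay, with a stated time of 72 h; on this read-out lower numbers stand for higher toxicity in this test and higher numbers for lower toxicity in this test. Compound 1, `Fc1ccccc1/C=N/c1sc2c(c1-c1nc3ccccc3s1)CCC2`, gives 270 ug/mL in this assay. Compound 2, `C(=N/c1sc2c(c1-c1nc3ccccc3s1)CCCC2)\c1ccccc1`, gives 71.1 ug/mL in this assay. Of the two numbers, compound 2 stands at the lower end, so it is the more toxic of the pair, and the gap to compound 1 is beyond the usual scatter. Since the two differ in more than one place, only their values are reported, not a single step.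

Compound 3, `C(=C/c1ccccc1)\C=N\c1sc2c(c1-c1nc3ccccc3s1)CCCC2`, has not yet been tested. Compared with compound 2, the change is 2-phenylethenyl in place of phenyl on a carbon with a double bond to nitrogen. Going by the values given here, no measured pair shows what this change does, so the expectation rests on the range already seen. With nothing pointing either way, the step from compound 2 to compound 3 is expected to be small, a 1.3-fold higher number from compound 2 to compound 3 (0.10 log units; within the scatter), likely within the scatter. Compound 3 is therefore estimated at 90 ug/mL, with a range from 35 ug/mL to 250 ug/mL.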

Compound 3, half-maximal cytotoxic concentration: 207 ug/mL
Beside the measured number, compound 3's estimate is 2.3-fold (0.36 log units) below it; low and high end bracket the measured number.
By their numbers in this assay, from the lowest: compound 2; then compounds 3 and 1 (each within the scatter of the next).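

Going by these compounds alone, this is the first measured step on a carbon with a double bond to nitrogen, and it shows that the number in this assay responds to a change at this position: putting 2-phenylethenyl in place of phenyl gives a 2.9-fold higher number from compound 2 to compound 3 (0.46 log units; beyond the scatter). A higher number on this read-out stands for lower toxicity in this test, so compound 3 is the less toxic member of this pair, even though both groups carry the same kind of aromatic ring and the entering group adds a double bond outside it. No measurement here explains what lies behind this step.

The compounds shown leave open whether the step depends on that added double bond or simply on the longer group, a question that a 2-phenylethyl group at the same place could help to answer. On these data alone, it also remains open how a group without an aromatic ring, such as a short alkyl chain or one ending in an amine, would behave here, and whether the same change would give a similar step on the core of compound 1.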